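The source may hold more compounds than are shown below. What is called first, only, known or untested is meant among the compounds shown, and "the series" means these compounds.

Measured so far:
compound 1 `[N-]=[N+]=Nc1nccc2ncn([C@H]3C[C@H](O)[C@@H](CO)O3)c12` — in a functional assay on the whole organism (Pleural cavity) with Rattus norvegicus as the target (on this read-out higher numbers stand for an effect only at larger amounts of compound and lower numbers for an effect already at smaller amounts), compound 1 gives > 9 mg/kg, which is a limit of the assay and not a number.
compound 2 `OC[C@H]1OC(n2cnc3c(Nc4ccccc4)nccc32)[C@H](O)[C@@H]1O` — in this assay compound 2 gives > 9 mg/kg, likewise a limit and not a number.

Compound 2 thus stands only at a limit, and it shares this position with compound 1, as the limit of > 9 mg/kg in this assay, at which 2 of the 2 values shown sit, records. Within the data shown here, no step between measured compounds is defined in this set, so nothing shows how a change at this part of the shared core moves the read-out. Compound 3 `CN(C)c1nccc2c1ncn2C1O[C@H](CO)[C@@H](O)[C@H]1O` differs from compound 2 by dimethylamino in place of anilino on an aromatic carbon. With both measured compounds sitting at the limit, no direction can be read from the data for this change. The step that the limit leaves unreadable from compound 2 to compound 3 is expected to stay within the scatter, with a fair chance that compound 3 again returns only a limit rather than a number. Compound 3 is estimated at 12 mg/kg, with a range from 3 mg/kg to 45 mg/kg.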

Compound 3, dose for half-maximal effect: > 9 mg/kg
Compound 3 ended at the assay's limit; the forecaster's own chance of this, stated with the estimate: 65%; the middle value is on the limit's open side.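

In this assay compound 3 gives > 9 mg/kg, a limit and not a number, so no step can be read between compound 2 and compound 3. The compounds shown leave open whether any change on the shared core moves the read-out, as all three stand at one place: the limit of > 9 mg/kg in this assay, at which 3 of the 3 values shown sit.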